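The source may hold more compounds than are shown below. What is called first, only, known or untested is meant among the compounds shown, and "the series" means these compounds.

Compound 1 `Cc1ccsc1CN[C@@H]1C[C@H]2C[C@@H]([C@H]1C)C2(C)C` gives 10000 nM in an ADME assay on MDCK cells (Canis lupus familiaris) for cytotoxicity, read by microscopy, with a stated time of 48 h (on this read-out higher numbers stand for lower toxicity in this test and lower numbers for higher toxicity in this test), the lowest of the three numbers measured. Compound 2 `CCCc1ccsc1CN[C@@H]1C[C@H]2C[C@@H]([C@H]1C)C2(C)C` gives 50000 nM and compound 3 `CCCCc1ccsc1CN[C@@H]1C[C@H]2C[C@@H]([C@H]1C)C2(C)C` gives 25000 nM. The measured steps, a 5.0-fold higher number from compound 1 to compound 2 (0.70 log units; beyond the scatter) and a 2.5-fold higher number from compound 1 to compound 3 (0.40 log units; beyond the scatter), come from adding a chain on a saturated chain carbon bound to an aromatic carbon; the step of a 2.0-fold lower number from compound 2 to compound 3 (0.30 log units; within the scatter) stays within the scatter.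

Compound 4 `C[C@H]1[C@H](NCc2cnccn2)C[C@H]2C[C@@H]1C2(C)C` differs from compound 1 in another place: pyrazin-2-yl in place of 3-methylthiophen-2-yl on a saturated chain carbon bound to an amine nitrogen. Among the measured compounds shown here, no measured step touches this position or exchanges one aromatic ring for another, so the known steps give no direct guide. Compound 4 is therefore expected to stay near compound 1, with a step of a 1.2-fold higher number from compound 1 to compound 4 (0.08 log units; within the scatter) that is not expected to pass the scatter. Compound 4 is estimated at 12000 nM, within a range from 4000 nM to 40000 nM.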

Compound 4, minimum cytotoxic concentration: > 100000 nM
Compound 4 gave a limit, no number; the forecaster's own chance of this, stated with the estimate: 10%; middle value at least 8.3-fold (0.92 log units) away from the limit.
By their numbers in this assay, from the lowest: compound 1; then compounds 3 and 2 (each within the scatter of the next). At a limit, above all of these: compound 4.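

The earlier compounds shown here changed only a chain on the ring, whereas here the ring itself is exchanged, and pyrazin-2-yl in place of 3-methylthiophen-2-yl gives an at least 10-fold higher number from compound 1 to compound 4 (1.00 log units; beyond the scatter) in this assay. This place can therefore move the read-out beyond the scatter, towards lower toxicity in this test. Compound 4 gives a limit and not a number, so the true size of this step stays unknown: the limit of > 100000 nM in this assay, at which 1 of the 4 values shown sits.

The compounds shown do not separate the change of ring from the loss of the methyl group. From the compounds shown here alone, whether a phenyl or pyridin-2-yl ring, or a pyrazin-2-yl ring carrying an amine, would behave the same way stays open.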